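The source may hold more compounds than are shown below. What is called first, only, known or untested is meant among the compounds shown, and "the series" means these compounds.

Among the measured compounds shown here, compound 1 `CCCCc1nc(N)c2nc(O)n(Cc3ccccc3)c2n1` is the only compound of the three for which a functional assay (spleen, spleen) for activation, with Mus musculus as the target (a higher number here means that more compound is needed for the effect, a lower number that less compound is needed), returns a number rather than a limit: in that assay compound 1 gives 0.03 uM. Compound 2 `COc1nc2c(N)ncnc2n1Cc1ccccc1` reaches only a limit of the assay, at > 10 uM. Compound 3 `Nc1ncnc2c1nc(O)n2-c1ccccc1` likewise sits at a limit, > 10 uM. Thus (the limit of > 10 uM in this assay, at which 2 of the 3 values shown sit). Compound 4 `Nc1nc(S)nc2c1nc(O)n2Cc1ccccc1` has not been measured; it differs from compound 1 by sulfanyl in place of butyl on an aromatic carbon. For the measured compounds named here, no step between measured compounds is known to calibrate this change, so the size of the step expected in this assay rests on judgment alone: a large loss of potency, well beyond the scatter, is expected, with an estimated 100-fold higher number from compound 1 to compound 4 (2.00 log units; beyond the scatter). Compound 4 is therefore estimated at 3 uM, expected to fall between 0.3 uM and 30 uM.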

Compound 4, minimum effective concentration: 10 uM
Estimate against measurement, compound 4: 3.3-fold (0.52 log units) below; low and high end bracket the measured number.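

Sulfanyl in place of butyl on this aromatic carbon, between two ring nitrogen atoms, gives the first step that can be read at this position: a 330-fold higher number from compound 1 to compound 4 (2.52 log units; beyond the scatter). What this carbon carries therefore matters strongly in this assay, with the rest of the core of compound 1 unchanged. Compound 4 reads at the very figure where the range of the assay ends: the limit of > 10 uM in this assay, at which 2 of the 4 values shown sit.

The compounds shown leave open whether the loss comes from removing butyl or from bringing in sulfanyl. A plain hydrogen, an amine, or a shorter or longer carbon chain on this carbon would separate the two.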